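The source may hold more compounds than are shown below. What is called first, only, known or untested is meant among the compounds shown, and "the series" means these compounds.

In a functional assay on HeLa cells (Homo sapiens) for antiproliferative activity, read by MTT assay, with a stated time of 48 h (a lower number here means a stronger inhibitor, a higher number a weaker inhibitor), compound 1 (`S=c1oc(-c2ccc3c(c2)OCCO3)nn1CN1CCN(c2cccc(Cl)c2Cl)CC1`) gives > 50000 nM as a limit of the assay and not a number. Compound 2 (`Fc1ccc(N2CCN(Cn3nc(-c4ccc5c(c4)OCCO5)oc3=S)CC2)cc1`) gives > 50000 nM as a limit too, so its standing is known only as a limit. The evidence so far is the limit of > 50000 nM in this assay, at which 2 of the 2 values shown sit, and no number exists yet for the series. Going by the values given here, the one measured step is a step that the two limits leave unreadable from compound 1 to compound 2 and it involves 4-fluorophenyl in place of 2,3-dichlorophenyl on an amine nitrogen in a ring.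

Compound 3 (`COc1ccc(N2CCN(Cn3nc(-c4ccc5c(c4)OCCO5)oc3=S)CC2)cc1`) differs from compound 2 by methoxy in place of fluoro on an aromatic carbon as the change from 4-fluorophenyl to 4-methoxyphenyl, that is, methoxy in place of fluoro on an aromatic carbon. Among the compounds with values here, no measured step has a readable size, so none can be carried over to this change. No step beyond the scatter is therefore expected in this assay in either direction, though this is a weak default and not a measured trend. The expected step is an at least 1.2-fold lower number from compound 2 to compound 3 (0.09 log units; that floor lies within the scatter) and no more than that. For compound 3 the estimate is 40000 nM with an expected range of 8000 nM to 60000 nM and a report as a limit once more is quite possible.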

Compound 3, half-maximal inhibitory concentration: > 50000 nM
Compound 3: only a limit was reported; the forecaster's own chance of this, stated with the estimate: 60%; at least 1.2-fold (0.09 log units) between middle value and limit.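

Going by these compounds alone, compound 1, compound 2 and compound 3 are all reported as limits of the assay and not as numbers, so no step among them can be read in this assay. The series rests on a single reading: the limit of > 50000 nM in this assay, at which 3 of the 3 values shown sit.

The compounds shown leave open whether any change on the phenyl group gives a measurable number in this assay.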